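The compounds below may be only part of what the source reports. "The series", "measured", "known", "first", "only" and "open" are said of these compounds alone.

Compound 1 `COc1cc(OC)c2c(=O)cc(-c3ccc(OCCCN(C)C)cc3)oc2c1` is the starting point of this account. In a functional assay (Homo sapiens) for antiproliferative activity, read by resazurin assay, with a stated time of 48 h, tested at 20 uM (a lower number here means a weaker effect, a higher number a stronger effect of the compound at the concentration tested), compound 1 gives 86%, the highest of the three numbers in hand. Compound 2 `COc1cc(OC)c2c(=O)cc(-c3ccc(OCCN4CCCC4=O)cc3)oc2c1` gives 33% and compound 3 `COc1cc(OC)c2c(=O)cc(-c3ccc(OCCN)cc3)oc2c1` gives 70%. Two measured steps start from compound 1: a number 53 percentage points lower from compound 1 to compound 2 (beyond the scatter), and a number 16 percentage points lower from compound 1 to compound 3 (beyond the scatter). A third step, a number 37 percentage points higher from compound 2 to compound 3 (beyond the scatter), runs between the two changed compounds. The unmeasured compound 4 `COc1cc(OC)c2c(=O)cc(-c3ccc(Br)cc3)oc2c1` differs from compound 1 as follows: bromo in place of 3-(dimethylamino)propoxy on an aromatic carbon. Going by the values given here, no measured step removes the whole 3-(dimethylamino)propoxy group, so the two steps that start from compound 1 are the nearest guides, and both lower the number, one by a large amount and one by a modest amount. Compound 4 is therefore expected to come in lower, by an estimated step of a number 56 percentage points lower from compound 1 to compound 4 (beyond the scatter). The estimated value of compound 4 in this assay is 30%, with an expected range from 8% to 58%.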

Compound 4, a percentage reported as inhibition, at one concentration (the size of the read-out at that concentration, not a potency): 22%
Estimate against measurement, compound 4: 8 percentage points above, within the range that was stated.
By their numbers in this assay, from the lowest: compound 4; then compound 2; then compound 3; then compound 1.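

In this assay, bromo in place of 3-(dimethylamino)propoxy gives a number 64 percentage points lower from compound 1 to compound 4 (beyond the scatter) and shows, as changes within the chain could not, the result of replacing the whole chain on this aromatic carbon with a single atom. The fall holds against the other two chains: bromo in place of 2-aminoethoxy gives a number 48 percentage points lower from compound 3 to compound 4 (beyond the scatter) and bromo in place of 2-(2-oxopyrrolidin-1-yl)ethoxy gives a number 11 percentage points lower from compound 2 to compound 4 (beyond the scatter) so even the chain with the lowest earlier number stands above bromo. Nothing measured here explains these falls.

The compounds shown leave open how much of the fall belongs to losing the chain and how much to the bromo itself, which a hydrogen or a methoxy on this carbon could help to separate. They also leave open how a longer chain or a chain ending in a morpholine would compare.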